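Triazole hydrazones of phenols: a third hydroxy group

The source may hold more compounds than are shown below. What is called first, only, known or untested is meant among the compounds shown, and "the series" means these compounds.

Measured so far in an assay for inhibition of Alpha amylase (Homo sapiens), with a stated time of 10 min; on this read-out lower numbers stand for stronger inhibition and higher numbers for weaker inhibition:
Compound 1, `Oc1ccc(/C=N/n2cnnc2)cc1`: 2990 nM
Compound 2, `Oc1ccc(/C=N/n2cnnc2)cc1O`: 5690 nM
Compound 3, `Oc1ccc(/C=N/n2cnnc2)c(O)c1`: 5950 nM

Three compounds share one core and differ only in the number of hydroxy groups on the benzene ring. Compound 1 carries one hydroxy group. Compound 2 and compound 3 each carry a second one, in different positions. Compound 3 stands level with the other two: its number matches that of compound 2 within the scatter, and the step of a 2.0-fold higher number from compound 1 to compound 3 (0.30 log units; within the scatter) likewise lies within the scatter, so none of the three can be ranked against the others.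

Compound 4, `Oc1ccc(/C=N/n2cnnc2)c(O)c1O`, is not yet measured. It arises from compound 3 by hydroxy in place of hydrogen on an aromatic carbon. The two measured steps that resemble this change are a 1.9-fold higher number from compound 1 to compound 2 (0.28 log units; within the scatter) and a 2.0-fold higher number from compound 1 to compound 3 (0.30 log units; within the scatter), each a hydroxy group added to a hydrogen-bearing aromatic carbon, and each stayed within the scatter. A third hydroxy group added in the same way is therefore expected to leave the number roughly where it is, or nudge it slightly upward, with a step of a 1.3-fold higher number from compound 3 to compound 4 (0.13 log units; within the scatter) that is estimated to stay within or just at the scatter. Compound 4 is expected to give about 8000 nM, with a likely range from 3500 nM to 18000 nM.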

Compound 4, half-maximal inhibitory concentration: 5920 nM
Compound 4: the middle estimate sits 1.4-fold (0.13 log units) above what was measured; the range from low to high includes it.
By their numbers in this assay, from the lowest: compounds 1, 2, 4 and 3 (each within the scatter of the next).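

In this assay, a hydroxy group on an aromatic carbon ortho to two hydroxy groups gives a 1.0-fold lower number from compound 3 to compound 4 (0.00 log units; within the scatter), and the same kind of addition starting from the other compound with two hydroxy groups gives a 1.0-fold higher number from compound 2 to compound 4 (0.02 log units; within the scatter). For the compounds shown here, the earlier steps added a second hydroxy group to a ring with only one, and adding a third to a ring that already has two also leaves the number within the scatter, so the first comparison of the change on two cores shows no measurable difference: the same change on two cores in this assay, a 1.9-fold higher number (0.28 log units; within the scatter) from compound 1 to compound 2 and a 1.0-fold lower number (0.00 log units; within the scatter) from compound 3 to compound 4, 1.9-fold (0.28 log units) apart, within the scatter of two such steps. The second comparison agrees: the same change on two cores in this assay, a 2.0-fold higher number (0.30 log units; within the scatter) from compound 1 to compound 3 and a 1.0-fold higher number (0.02 log units; within the scatter) from compound 2 to compound 4, 1.9-fold (0.28 log units) apart, within the scatter of two such steps.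

All four compounds carry only hydroxy groups on the ring, and every step among them lies within the scatter, so these compounds do not show which ring substituents, if any, would move the number beyond it. As far as these compounds go, whether a methoxy group, an amine or a carboxylic acid on this same aromatic carbon would give a different number remains open.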